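Replacing 1H-indol-1-yl with piperazin-1-yl on a sulfonyl sulfur

The source may report more compounds than this note shows. Statements on the series, on what has been measured and on what is new or still open speak of the compounds shown alone.

Compound 1 `O=C(O)c1ccccc1-n1nc(C(F)(F)F)cc1C(=O)Nc1ccc(S(=O)(=O)N2CCCC2)cc1` has the entry "not determined" (no result reported) in an ADME assay on Vero cells (Chlorocebus sabaeus) for cytotoxicity, read by MTT assay (on this read-out higher numbers stand for lower toxicity in this test and lower numbers for higher toxicity in this test), and so offers no number to compare. Compound 2 `Cn1nc(C(F)(F)F)cc1C(=O)Nc1ccc(S(=O)(=O)N2CCC[C@H]2C(=O)OC(=O)c2ccccc2)cc1` gives 100000 nM in this assay and compound 3 `Cn1nc(C(F)(F)F)cc1C(=O)Nc1ccc(S(=O)(=O)n2ccc3ccccc32)cc1` gives 13000 nM in the same test. That makes compound 3 the lower of the two numbers, with a gap that lies beyond the usual scatter.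

Compound 4 `Cn1nc(C(F)(F)F)cc1C(=O)Nc1ccc(S(=O)(=O)N2CCNCC2)cc1` has yet to be measured. The structural change piperazin-1-yl in place of 1H-indol-1-yl on a sulfonyl sulfur puts piperazin-1-yl in place of 1H-indol-1-yl on a sulfonyl sulfur. Among the compounds with values here, no measured pair shows this kind of change directly, so any expectation rests on thin evidence. Like compound 4, compound 2 carries a non-aromatic ring on a sulfonyl sulfur, and compound 2 reaches 100000 nM in this assay despite its other differences. A rise beyond the scatter is therefore expected, and the estimated change a 3.8-fold higher number from compound 3 to compound 4 (0.59 log units; beyond the scatter) remains tentative with so few numbers. The estimate for compound 4 is 50000 nM with an expected range from 15000 nM to 150000 nM at its upper end.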

Compound 4, half-maximal cytotoxic concentration: 126000 nM
Compound 4: the middle estimate sits 2.5-fold (0.40 log units) below what was measured; measured number inside the range.
By their numbers in this assay, from the lowest: compound 3; then compounds 2 and 4 (each within the scatter of the next).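

Within the data shown here, this is the first direct comparison of two groups on the sulfonyl sulfur with the rest of the molecule unchanged. In this assay, piperazin-1-yl in place of 1H-indol-1-yl gives a 9.7-fold higher number from compound 3 to compound 4 (0.99 log units; beyond the scatter), a step beyond the scatter towards lower toxicity in this test, so the group at this place clearly affects the read-out. No measurement shown here explains the step.

The change removes two aromatic rings and brings in a non-aromatic ring with a second nitrogen and a hydrogen-bond donor, so the compounds shown leave open which of these features matters. A morpholin-4-yl ring or an open-chain dimethylamino group on the same sulfonyl sulfur would help separate the role of the ring's hydrogen-bond donor from the loss of the aromatic rings.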